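The source may hold more compounds than are shown below. What is called first, only, known or untested is meant among the compounds shown, and "the series" means these compounds.

Of the compounds shown here, three sharing one core have been tested in a functional assay on SW-620 cells (Homo sapiens) for inhibition, read by MTT assay, with a stated time of 72 h; on this read-out higher numbers stand for weaker inhibition and lower numbers for stronger inhibition. Compound 1 `O=C1O/C(=C\Cn2ncc(=O)[nH]c2=O)C(OCc2ccccc2)=C1OCc1ccccc1` gives 36500 nM in this assay. For compound 2 `Nc1ccn(C[C@H](O)[C@H]2OC(=O)C(OCc3ccccc3)=C2OCc2ccccc2)c(=O)n1` the result is only a limit, > 100000 nM, and not a number. Compound 3 `NC1(CCn2cc(F)c(=O)[nH]c2=O)OC(=O)C(OCc2ccccc2)=C1OCc1ccccc1` likewise reaches only a limit, > 100000 nM. Among the compounds with values here, compound 2 therefore stands at the weak end of what has been seen so far, sitting at the limit of > 100000 nM in this assay, at which 2 of the 3 values shown sit, while compound 1 is the one compound with a measured number.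

Compound 4 `O=C1O[C@H]([C@@H](O)Cn2ccc(NC(=O)c3ccccc3)nc2=O)C(OCc2ccccc2)=C1OCc1ccccc1` has not yet been measured. It differs from compound 2 in a single place: benzoyl in place of hydrogen on a nitrogen on an aromatic ring, which read one bond further out turns amino into benzamido. Within the data shown here, no step between two measured compounds shows what such a change does on this core, so the expectation rests on where compound 2 sits and on the change itself. A step of modest size, if any, is anticipated, and the estimated step of an at least 1.4-fold lower number from compound 2 to compound 4 (0.15 log units; that floor lies within the scatter) is expected to stay close to the scatter of the method. Compound 4 is thus expected to give about 70000 nM in this assay, with a range from 20000 nM to 200000 nM, and a real chance that only a limit is reported again.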

Compound 4, half-maximal inhibitory concentration: > 100000 nM
Compound 4 gave a limit, no number; the forecaster's own chance of this, stated with the estimate: 55%; middle value at least 1.4-fold (0.15 log units) from the limit.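

Compound 2 and compound 4 both end at a limit of the assay and not at a number, so no step between them can be read: the limit of > 100000 nM in this assay, at which 3 of the 4 values shown sit.

The compounds shown leave open whether benzoyl in place of hydrogen on a nitrogen on an aromatic ring changes the result in this assay at all, in either direction.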